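Ester to primary amide in a non-cytotoxic series

This account rests on a few compounds, and the source may have more. Where it says the series, first, only, none or still open, it means among the compounds named here.

Compound 1 `COC(=O)C[C@H](NC(=O)OC(C)(C)C)C(=O)N(Cc1ccc(F)cc1)C1(C(=O)NCc2ccccc2)CCN(Cc2ccccc2)CC1` was examined in an ADME assay on MDCK cells (Canis lupus familiaris) for cytotoxicity, read by microscopy, with a stated time of 72 h; on this read-out lower numbers stand for higher toxicity in this test and higher numbers for lower toxicity in this test. In this assay compound 1 gives > 100000 nM, which is a limit of the assay and not a measured number. Two neighbours differ from it in one place. Compound 2 `COC(=O)C[C@H](NC(=O)OC(C)(C)C)C(=O)N(Cc1ccc(F)cc1)C1(C(=O)NC2CCCCC2)CCN(Cc2ccccc2)CC1` carries cyclohexyl in place of benzyl on an amide-type nitrogen, and in this assay compound 2 gives 100000 nM. Compound 3 `COC(=O)C[C@H](NC(=O)OC(C)(C)C)C(=O)N(Cc1ccc(Cl)cc1)C1(C(=O)NCc2ccccc2)CCN(Cc2ccccc2)CC1` carries chloro in place of fluoro on an aromatic carbon, and in this assay compound 3 gives 100000 nM. The step of a number no higher from compound 1 to compound 2 (the limit leaves the size open) and the step of a number no higher from compound 1 to compound 3 (the limit leaves the size open) cannot be sized because compound 1 sits at the limit of > 100000 nM in this assay, at which 1 of the 3 values shown sits.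

Compound 4 `CC(C)(C)OC(=O)N[C@@H](CC(N)=O)C(=O)N(Cc1ccc(F)cc1)C1(C(=O)NCc2ccccc2)CCN(Cc2ccccc2)CC1` has not yet been measured. It differs from compound 1 by amino in place of methoxy on a carbonyl carbon. Neither measured step touches this part of the molecule; the two known changes, on the amide-type nitrogen and on the aromatic carbon, both leave the value at or next to the limit. The same is expected here, with no step beyond the scatter. The step this estimate means is a number no higher from compound 1 to compound 4 (the limit leaves the size open). Compound 4 is expected to give 100000 nM in this assay, within a range from 50000 nM to 200000 nM, quite possibly again only as a limit.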

Compound 4, minimum cytotoxic concentration: > 100000 nM
Compound 4: a limit, no number; the forecaster's own chance of this, stated with the estimate: 65%; the middle value lies on the limit itself.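

In this assay compound 4 gives > 100000 nM, which is a limit of the assay and not a number. For the compounds shown here, compound 1 and compound 4 both sit at a limit, so no step between them can be read: the limit of > 100000 nM in this assay, at which 2 of the 4 values shown sit. The compounds shown leave open whether amino in place of methoxy on a carbonyl carbon changes the minimum cytotoxic concentration at all.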